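The compounds below may be only part of what the source reports. "The series", "measured", "known", "first", "only" and "open" are said of these compounds alone.

Results so far in a functional assay on LoVo cells (Homo sapiens) for cytotoxicity, read by colorimetric assay and MTT assay; on this read-out higher numbers stand for weaker inhibition and lower numbers for stronger inhibition

compound 1 `COc1ccc(-c2cc3cccc(OC)c3nc2O)cc1` gives 10000 nM
compound 2 `COc1cc(OC)c2cc(-c3ccc(OCc4ccccc4)cc3)c(O)nc2c1` gives 10000 nM
compound 3 `COc1ccc(-c2cc3c(OC)cc(OC)cc3n(CC#N)c2=O)cc1` gives 10000 nM

Compound 3 stands level with compounds 1 and 2, so this small set shows no trend to build on. The next compound, compound 4 `CCN(CC)C(=O)CCn1c(=O)c(-c2ccc(OC)cc2)cc2c(OC)cc(OC)cc21`, keeps the core of compound 3 and changes one group. On a saturated chain carbon bound to an aromatic nitrogen, (diethylcarbamoyl)methyl comes in place of cyano (diethylcarbamoyl)methyl in place of cyano on a saturated chain carbon bound to an aromatic nitrogen and the rest of the structure stays the same. Going by the values given here, no two measured compounds differ in only one place, so the data give no direct guide to a swap of this kind. Among the compounds with values here, with compound 3 at 10000 nM and no measured compound away from that level, no step beyond the scatter is expected in this assay in either direction. The estimated move is no change at the digits printed from compound 3 to compound 4 (within the scatter) on this reasoning. The estimate for compound 4 is 10000 nM with an expected range from 3000 nM to 20000 nM until the measurement is in.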

Compound 4, half-maximal inhibitory concentration: 10000 nM
For compound 4 middle estimate and measured number coincide at the digits printed, within the range that was stated.
By their numbers in this assay, from the lowest: compounds 1, 2, 3 and 4 (each within the scatter of the next).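

In this assay the swap of cyano for (diethylcarbamoyl)methyl on a saturated chain carbon bound to an aromatic nitrogen brings no change at the digits printed from compound 3 to compound 4 (within the scatter) and gives this set its first comparison of two compounds that differ in one place. At this position, then, a group of 8 heavy atoms in place of one of 2 heavy atoms leaves the number where it was, so the added size and the new carbonyl bring no visible gain or loss here. Nothing measured on these compounds offers a reason for this flat result.

On these data alone, with all four compounds at the same printed level, it remains open whether any change at this position can move the number at all. An amine, a carboxylic acid or a longer chain in place of cyano on this saturated chain carbon could still give a different answer.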